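The source may hold more compounds than are shown below. What is called first, only, known or untested is meant among the compounds shown, and "the series" means these compounds.

Measured in an ADME assay on microsomes from liver (Mus musculus) for metabolic stability; a lower number here means that the compound disappears faster, a higher number that the compound lasts longer:
- compound 1 `NS(=O)(=O)CC(=O)NCCSc1nonc1/C(=N/O)Nc1cccc(C(F)F)c1`: 1.5 h
- compound 2 `NS(=O)(=O)CC(=O)NCCSc1nonc1/C(=N/O)Nc1ccc(F)c(Br)c1`: 1.12 h

In this assay compound 2 stands at 1.12 h, within the scatter of compound 1 at 1.5 h. Compound 3 `N#Cc1cccc(N/C(=N\O)c2nonc2SCCNC(=O)CS(N)(=O)=O)c1` has 3-cyanophenyl in place of 3-bromo-4-fluorophenyl on an amine nitrogen.

Among the compounds with values here, one measured step bears on this change: a 1.3-fold lower number from compound 1 to compound 2 (0.13 log units; within the scatter). It is an exchange of the aryl group at the same place, and it stays within the scatter. Within the data shown here, a single step is thin evidence, and no measured compound carries the nitrile. On this basis, no step beyond the scatter is expected in this assay, and no direction can be assigned.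

The step expected is a 1.2-fold higher number from compound 2 to compound 3 (0.06 log units; within the scatter). Compound 3 is estimated at 1.3 h, with an expected range of 0.6 h to 2.6 h.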

Compound 3, half-life: > 3 h
Compound 3: only a limit was reported; the forecaster's own chance of this, stated with the estimate: 5%; middle value at least 2.3-fold (0.36 log units) from the limit.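

In this assay, compound 3 stands at > 3 h, which is a limit of the assay and not a number: the limit of > 3 h in this assay, at which 1 of the 3 values shown sits.

The aryl group on the amine nitrogen is now shown to move this read-out, with an at least 2.6-fold higher number from compound 2 to compound 3 (0.42 log units; beyond the scatter), whereas the earlier aryl exchange, a 1.3-fold lower number from compound 1 to compound 2 (0.13 log units; within the scatter), stayed within the scatter. Against the other aryl group the picture is less firm: the exchange of difluoromethyl for cyano on an aromatic carbon gives an at least 2.0-fold higher number from compound 1 to compound 3 (0.30 log units; that floor lies within the scatter), so this floor alone does not separate the two compounds.

On these data alone, how far compound 3 lies past its limit remains open, as does whether the step from compound 2 follows from the entering nitrile or from the departing bromine and fluorine. As far as these compounds go, whether a primary amide or a methoxy group on the same aromatic ring would behave like the nitrile also remains open.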